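The source may report more compounds than this note shows. Statements on the series, on what has been measured and on what is new or still open speak of the compounds shown alone.

In a functional assay on U-937 cells (Homo sapiens), read by cAMP accumulation (a lower number here means that less compound is needed, a higher number that more compound is needed for the effect), compound 1 (`CCc1nn(C2CCCC2)c2c1CCN(c1ccccc1C)C2=O`) gives 330 nM, the lower of the two numbers available. Within the data shown here, the only other measured compound, compound 2 (`CCCCc1nn(-c2ccc(F)cc2)c2c1CCN(c1ccccc1)C2=O`), gives 13000 nM, a gap beyond the scatter. However, compound 2 differs from compound 1 in more than one place, so this gap isolates no single change. Compound 3 (`CCc1nn(C2CCCC2)c2c1CCN(c1cccnc1)C2=O`) keeps the core of compound 1 but carries pyridin-3-yl in place of 2-methylphenyl on an amide-type nitrogen in a ring. Among the measured compounds shown here, no measured pair shows this exchange, so the expectation is loose and starts from the value of compound 1 alone. A moderate move toward a higher number, beyond the scatter, is expected, with the estimated step being a 3.0-fold higher number from compound 1 to compound 3 (0.48 log units; beyond the scatter). For compound 3 the expected value is 1000 nM, with an estimated range of 200 nM to 6000 nM.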

Compound 3, half-maximal effective concentration: 17 nM
The estimate for compound 3 lay 59-fold (1.77 log units) above the measured number; measured number below the stated range.
By their numbers in this assay, from the lowest: compound 3; then compound 1; then compound 2.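

In this assay, the group on the amide-type nitrogen in a ring strongly affects the number: with the rest of compound 1 unchanged, pyridin-3-yl in place of 2-methylphenyl gives a 19-fold lower number from compound 1 to compound 3 (1.29 log units; beyond the scatter) and this large step lies beyond the scatter. Unlike the gap between compound 1 and compound 2, this difference can be assigned to a single place. It also shows that a six-membered aromatic ring with one ring nitrogen at this position gives a lower number than 2-methylphenyl, and no available measurement explains the step.

From the compounds shown here alone, the exchange removes a methyl group and adds a ring nitrogen together, so the contribution of each remains open. How pyridin-2-yl, pyridin-4-yl or a methyl-substituted pyridin-3-yl would compare at this position also remains an open question.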